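From methyl to phenyl: expected inhibition of compound 3

The source may report more compounds than this note shows. Statements on the series, on what has been measured and on what is new or still open speak of the compounds shown alone.

Measured compounds in a functional assay on the whole organism (heart, strain mongrel) for inhibition, with Canis familiaris (Canis lupus familiaris) as the target, with a stated time of 20 min, at a dose of 0.42 mg/kg by the intravenous route; on this read-out lower numbers stand for a weaker effect and higher numbers for a stronger effect at the one dose given:
compound 1 `CC(C)(C)NCC(O)COc1ncns1` gives 49.5%
compound 2 `Cc1nsc(OCC(O)CNC(C)(C)C)n1` gives 24.2%

For the measured compounds named here, compound 2 stands lowest of the two measured numbers; its nearest neighbour is compound 1, and the one known step, a number 25.3 percentage points lower from compound 1 to compound 2 (beyond the scatter), lies beyond the scatter. Compound 3 `CC(C)(C)NCC(O)COc1nc(-c2ccccc2)ns1` differs from compound 2 by phenyl in place of methyl on an aromatic carbon. Going by the values given here, no measured step shows a phenyl entering at this place; the only step at this carbon is the one from hydrogen to methyl, which lowered the read-out, so that step gives a direction but only a loose guide to a change of a different size. A further modest fall, or no change beyond the scatter, is expected for compound 3 in this assay, as a number 9.2 percentage points lower from compound 2 to compound 3 (within the scatter). Compound 3 is therefore estimated at 15%, within a range from 0% to 40%.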

Compound 3, a percentage reported as inhibition, in the whole organism at one dose (the size of the read-out at that dose, not a potency): 5.7%
The estimate for compound 3 lay 9.3 percentage points above the measured number; measured number inside the range.
By their numbers in this assay, from the lowest: compound 3; then compound 2; then compound 1.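

In this assay, for the compounds shown here, the aromatic carbon between two ring nitrogen atoms now shows a second fall: phenyl in place of methyl gives a number 18.5 percentage points lower from compound 2 to compound 3 (beyond the scatter), and phenyl in place of hydrogen gives a number 43.8 percentage points lower from compound 1 to compound 3 (beyond the scatter), the only large step among the three compounds. Hydrogen, methyl and phenyl at this carbon thus stand in falling order, with no compound shown against that order, so the direction seen with methyl also holds for a group with a six-membered aromatic ring. Nothing available explains why the read-out falls with these groups.

From the compounds shown here alone, whether an amine or a methoxy group at this carbon would also lower the read-out remains open. So does whether a substituted phenyl would fall in the same order, and the single dose gives the size of the effect, not a potency.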